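The source may report more compounds than this note shows. Statements on the series, on what has been measured and on what is new or still open speak of the compounds shown alone.

Measured in a functional assay on HepG2 cells (Homo sapiens) for antiproliferative activity, read by CCK-8 assay, with a stated time of 48 h; a higher number here means a weaker inhibitor, a lower number a stronger inhibitor:
- Compound 1 `COc1ccc(/C=C\c2cc(OC)c(OC)c(OC)c2)cc1OCc1ccc(CN2C[C@H](O)C[C@@H]2C(=O)O)cc1`: > 10000 nM, a limit and not a number
- Compound 2 `COc1ccc(/C=C\c2cc(OC)c(OC)c(OC)c2)cc1OCc1ccc(CNCCO)cc1`: 5900 nM
- Compound 3 `COc1ccc(/C=C\c2cc(OC)c(OC)c(OC)c2)cc1OCc1ccc(CO)cc1`: 2400 nM

Compound 3 has the lower of the two actual numbers, and compound 2 is its nearest neighbour. The value for compound 1 is a limit. The next compound, compound 4 `COc1ccc(/C=C\c2cc(OC)c(OC)c(OC)c2)cc1OCc1ccc(CNCCN(C)C)cc1`, carries (2-(dimethylamino)ethyl)amino in place of hydroxy on a saturated chain carbon bound to an aromatic carbon.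

The closest evidence is the exchange between the hydroxy group and the (2-hydroxyethyl)amino group, which gave a 2.5-fold lower number from compound 2 to compound 3 (0.39 log units; beyond the scatter). Compound 4 makes a related exchange in the opposite direction, so a modest rise in the number is the likeliest outcome. The step of an at least 4.1-fold lower number from compound 1 to compound 3 (0.61 log units; beyond the scatter) also favours the hydroxy group, but it rests on a limit and involves a different group, so it gives only the direction. Neither step shows how the terminal dimethylamino group of compound 4 will compare with the terminal hydroxy group of compound 2, so the expectation remains broad.

In this assay, the expected step is a 1.9-fold higher number from compound 3 to compound 4 (0.27 log units; within the scatter). Compound 4 is estimated at 4500 nM, with an expected range of 1500 nM to 10000 nM.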

Compound 4, half-maximal inhibitory concentration: 4400 nM
Estimate against measurement, compound 4: 1.0-fold (0.01 log units) above; low and high end bracket the measured number.
By their numbers in this assay, from the lowest: compounds 3, 4 and 2 (each within the scatter of the next, the first and the last beyond it). At a limit, above all of these: compound 1.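

In this assay, dimethylamino at the end of the chain cannot be told apart from the hydroxy of compound 2, with a 1.3-fold lower number from compound 2 to compound 4 (0.13 log units; within the scatter). The change at the saturated chain carbon bound to an aromatic carbon from hydroxy to (2-(dimethylamino)ethyl)amino, which brings in 6 heavy atoms for 1, gives a 1.8-fold higher number from compound 3 to compound 4 (0.26 log units; within the scatter), so this larger group, unlike the (2-hydroxyethyl)amino group of compound 2, is not separated from the hydroxy of compound 3 by more than the scatter. The replacement of 2-carboxy-4-hydroxypyrrolidin-1-yl gives an at least 2.2-fold lower number from compound 1 to compound 4 (0.35 log units; beyond the scatter), a floor and not a measured size, resting on the value of compound 1, which is a limit: the limit of > 10000 nM in this assay, at which 1 of the 4 values shown sits.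

The compounds shown leave open whether a longer chain between the two nitrogens, or a terminal piperidine or morpholine ring, would move the number beyond the scatter of compounds 3 and 4. They also do not separate the carboxylic acid of compound 1 from its pyrrolidine ring, so a pyrrolidine without the acid remains an open comparison.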